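The compounds below may be only part of what the source reports. "The series", "measured", "known", "first", "only" and "open" are said of these compounds alone.

Measured so far in an ADME assay on Huh-5-2 cells (Homo sapiens) for cytotoxicity; on this read-out lower numbers stand for higher toxicity in this test and higher numbers for lower toxicity in this test:
compound 1 `Cc1ccc(C#Cc2nc(C(N)=O)nn2COCCO)cc1` — compound 1 gives > 50 ug/mL, a limit of the assay and not a number.
compound 2 `CCCCCc1ccc(C#Cc2nc(C(N)=O)nn2COCCO)cc1` — compound 2 gives 25 ug/mL.
compound 3 `NC(=O)c1nc(C#Cc2ccc(C(F)(F)F)cc2)n(COCCO)n1` — compound 3 gives 20 ug/mL.

Compound 1 stands only at a limit, (the limit of > 50 ug/mL in this assay, at which 1 of the 3 values shown sits); no number is known for it. The two steps away from it run: an at least 2.0-fold lower number from compound 1 to compound 2 (0.30 log units; that floor lies within the scatter), and an at least 2.5-fold lower number from compound 1 to compound 3 (0.39 log units; beyond the scatter). Between the two numbered compounds, a 1.3-fold lower number from compound 2 to compound 3 (0.10 log units; within the scatter).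

Compound 4 `NC(=O)c1nc(C#CCCCCl)n(COCCO)n1` differs from compound 1 by 3-chloropropyl in place of 4-methylphenyl on a triple-bonded carbon. Neither measured step resembles this change: the step from compound 1 to compound 2 adds butyl on a saturated chain carbon, the step from compound 1 to compound 3 puts trifluoromethyl in place of methyl on an aromatic carbon, and both keep the 4-methylphenyl that here leaves for 3-chloropropyl. The measured moves away from compound 1 have lowered the number, by amounts that are floors only. For compound 4 no step beyond the scatter is expected in this assay, so the expected step is a number no higher from compound 1 to compound 4 (the limit leaves the size open). Compound 4 is therefore estimated at 50 ug/mL, between 20 ug/mL and 100 ug/mL, with a real chance that only a limit is again returned.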

Compound 4, half-maximal cytotoxic concentration: > 50 ug/mL
Compound 4: a limit, no number (the forecaster's own chance of this, stated with the estimate: 50%); the middle value lies on the limit itself.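

No step from compound 1 to compound 4 can be read in this assay, because both compounds return only a limit and no number: the limit of > 50 ug/mL in this assay, at which 2 of the 4 values shown sit.

The compounds shown leave open whether 3-chloropropyl in place of 4-methylphenyl on a triple-bonded carbon changes the read-out at all, and in which direction.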